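From 4-methylphenyl to 4-bromophenyl: working notes

The compounds below may be only part of what the source reports. "The series", "measured", "known", "first", "only" and "open" are said of these compounds alone.

- compound 1 `Cc1ccc(-c2cc(NC(=O)c3ccc(Br)nc3)n[nH]2)cc1`: 6780 nM
- compound 2 `COc1ccc(C(=O)Nc2cc(-c3ccc(C)cc3)[nH]n2)cn1`: 7350 nM

Both values come from a functional assay on WM 266-4 cells (Homo sapiens) for antiproliferative activity, read by MTT assay, with a stated time of 48 h; a higher number here means a weaker inhibitor, a lower number a stronger inhibitor. Going by the values given here, compound 1 lies within the scatter of compound 2, the only other measured compound, so the two cannot be ranked. Compound 3 `O=C(Nc1cc(-c2ccc(Br)cc2)[nH]n1)c1ccc(Br)nc1` is not yet measured. Its change is bromo in place of methyl on an aromatic carbon, para to a large group. Among the compounds with values here, the one measured step, a 1.1-fold higher number from compound 1 to compound 2 (0.04 log units; within the scatter), puts methoxy in place of bromo elsewhere in the molecule, so it bears only indirectly on this change. No shift beyond the scatter is expected in this assay, and the estimated step is a 1.1-fold lower number from compound 1 to compound 3 (0.05 log units; within the scatter). Compound 3 is expected at 6000 nM, within an estimated range of 2500 nM to 14000 nM.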

Compound 3, half-maximal inhibitory concentration: 8560 nM
For compound 3 the middle estimate is 1.4-fold (0.15 log units) below the measured one; low and high end bracket the measured number.
By their numbers in this assay, from the lowest: compounds 1, 2 and 3 (each within the scatter of the next).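

In this assay, the step of a 1.3-fold higher number from compound 1 to compound 3 (0.10 log units; within the scatter) shows that, at this place on the aromatic ring, para to a large group, 4-methylphenyl and 4-bromophenyl cannot be told apart. Going by these compounds alone, the earlier step concerned a different place, so this is the first reading of this position, and a heavy atom of carbon or bromine here is tolerated equally within the scatter. No evidence on the cause of this result is available. As far as these compounds go, whether an amine or a carboxylic acid at this position would shift the number beyond the scatter stays open.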